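Ethynyl in place of hydrogen on the pentyl chain

A few compounds are considered here, and "the series" means these few. Any claim that something is new, unique, unknown or untested is made for them only; others in the source may bear on it.

Compound 1 `CCCCCc1cc2cn([C@H]3C[C@H](O)[C@@H](CO)O3)c(=O)nc2o1` is the starting point. In a functional assay on HEL cells (Homo sapiens) for cytotoxicity, read by microscopy (a higher number here means that more compound is tolerated, a lower number that less compound is tolerated), compound 1 gives > 50000 nM, which is a limit of the assay rather than a number. Going by the values given here, its one neighbour that differs in a single place, compound 2 `CCCCCCCCCCc1cc2cn([C@H]3C[C@H](O)[C@@H](CO)O3)c(=O)nc2o1`, likewise reaches only a limit in this assay, namely > 50000 nM. The step that the two limits leave unreadable from compound 1 to compound 2 therefore cannot be read in size or direction; what the data show is the limit of > 50000 nM in this assay, at which 2 of the 2 values shown sit. The unmeasured compound 3 `C#CCCCCCc1cc2cn([C@H]3C[C@H](O)[C@@H](CO)O3)c(=O)nc2o1` differs from compound 1 by ethynyl in place of hydrogen on a saturated chain carbon, five bonds along the chain from an aromatic carbon. Among the compounds with values here, no measured step bears on this change beyond the two limits, so no movement beyond the scatter can be argued from them. Compound 3 is expected to sit at the same limit, with an estimated step that the limit leaves unreadable from compound 1 to compound 3. The estimate for compound 3 in this assay is 60000 nM, ranging from 20000 nM to 200000 nM.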

Compound 3, minimum cytotoxic concentration: > 200000 nM
Compound 3 gave a limit, no number; the forecaster's own chance of this, stated with the estimate: 85%; middle value at least 3.3-fold (0.52 log units) away from the limit.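

Compound 3, like compound 1 and compound 2, reaches only a limit in this assay, so no step among these three compounds can be read in size or direction. The compounds shown leave open at what concentration any of them becomes cytotoxic, and whether their chains differ in this respect at all.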